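Amide in place of acid on the side chain

A few compounds are considered here, and "the series" means these few. Any claim that something is new, unique, unknown or untested is made for them only; others in the source may bear on it.

Notes on the series. Compound 2 `O=C(O)CCCn1nc(-c2cccnc2)c2ccccc2c1=O` carries a carboxy group at the end of the chain on the shared core. Among the compounds with values here, in an assay on isolated protein (Oryctolagus cuniculus) with Thromboxane-A synthase (Homo sapiens) as the target, tested at 1 uM (on this read-out lower numbers stand for less inhibition and higher numbers for more inhibition at the one concentration tested (going by the name of the read-out)), compound 2 gives 73%, the lowest of the two numbers so far. Within the data shown here, its nearest neighbour is compound 1 `O=c1c2ccccc2c(-c2cccnc2)nn1CCCCSc1ncccn1`, which in this assay gives 96%; the step of a number 23 percentage points lower from compound 1 to compound 2 (beyond the scatter) is the only measured step and lies beyond the scatter.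

Compound 3 `CC(C)NC(=O)CCCn1nc(-c2cccnc2)c2ccccc2c1=O` is the next step from compound 2: isopropylamino in place of hydroxy on a carbonyl carbon. Among the measured compounds shown here, no measured step covers this exact change, so the one step at hand, from compound 1 to compound 2, is taken only as a sign that the terminal group of the chain matters here.

For compound 3 an increase is expected in this assay, the step being a number 9 percentage points higher from compound 2 to compound 3 (within the scatter). The estimate for compound 3 in this assay is 82%, with a range from 65% to 95%.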

Compound 3, a percentage reported as inhibition, at one concentration (the size of the read-out at that concentration, not a potency): 89%
Estimate against measurement, compound 3: 7 percentage points below; low and high end bracket the measured number.
By their numbers in this assay, from the lowest: compound 2; then compounds 3 and 1 (each within the scatter of the next).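

Isopropylamino in place of hydroxy on a carbonyl carbon gives a number 16 percentage points higher from compound 2 to compound 3 (beyond the scatter) in this assay, so the lower number of compound 2 does not extend to every chain ending in a carbonyl group. With a number 7 percentage points lower from compound 1 to compound 3 (within the scatter), isopropylcarbamoyl and ((pyrimidin-2-yl)sulfanyl)methyl cannot be told apart at this place on the shared core, although the two end groups differ in kind. Nothing available bears on why the amide and the acid differ.

Still open, going by these compounds, is whether a smaller amide such as the methylamide, a tertiary amide such as the dimethylamide, or a longer chain carrying the isopropylcarbamoyl group would keep the number of compound 3. On these data alone, because the read-out stands at one concentration, how compound 1 and compound 3 compare in potency also remains open.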